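Swapping the halogen on the anilide ring: fluoro to chloro

The source may report more compounds than this note shows. Statements on the series, on what has been measured and on what is new or still open speak of the compounds shown alone.

Measured so far:
- compound 1, `Cc1cc(C)cc(NC(=O)CN2CCC(c3cccc[n+]3[O-])CC2)c1`, efficacy 76%
- compound 2, `Cc1cc(F)ccc1NC(=O)CN1CCC(c2cccc[n+]2[O-])CC1`, efficacy 84%

Both compounds share one core and differ only in the aromatic group carried on the amide-type nitrogen. In a functional assay on HEK293 cells for agonist activity at D(4) dopamine receptor (Homo sapiens), read by FLIPR (a lower number here means a smaller maximal response, a higher number a larger maximal response), compound 1 reaches 76% and compound 2 reaches 84%. For the measured compounds named here, the only step available, a number 8 percentage points higher from compound 1 to compound 2 (within the scatter), is within the scatter, so the two values cannot be ranked against each other; compound 2 simply sits at one end of a pair whose numbers are indistinguishable.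

The next compound, compound 3, `Cc1ccc(Cl)cc1NC(=O)CN1CCC(c2cccc[n+]2[O-])CC1`, keeps everything else and changes the aromatic group once more: 5-chloro-2-methylphenyl in place of 4-fluoro-2-methylphenyl on an amide-type nitrogen. Going by the values given here, the one measured step bears on it only loosely, since it exchanged a whole ring pattern rather than one halogen, and it showed no movement beyond the scatter. With no sign that this part of the molecule shifts the maximal response, a step of about a number 4 percentage points lower from compound 2 to compound 3 (within the scatter) from compound 2 to compound 3 is expected, that is, none beyond the scatter. Compound 3 is therefore estimated at 80%, with a range from 66% to 94%.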

Compound 3, largest response reached (reported as efficacy), in percent of the reference or control that the assay uses: 58%
Compound 3: middle estimate off by 22 percentage points, on the high side, outside the stated range (below it).
By their numbers in this assay, from the lowest: compound 3; then compounds 1 and 2 (each within the scatter of the next).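

In this assay the aromatic group on the amide-type nitrogen clearly affects the maximal response: 5-chloro-2-methylphenyl in place of 4-fluoro-2-methylphenyl gives a number 26 percentage points lower from compound 2 to compound 3 (beyond the scatter) and 5-chloro-2-methylphenyl in place of 3,5-dimethylphenyl gives a number 18 percentage points lower from compound 1 to compound 3 (beyond the scatter) so compound 3 stands lowest of the three. The first of these swaps leaves the heavy-atom count, the aromatic ring and the lack of hydrogen-bond donors and acceptors unchanged, so a change that looks small on paper can still shift this read-out. Nothing measured here explains why the response falls.

The step from compound 2 to compound 3 changes both the halogen and its number in the group's name, so it cannot be assigned to either change alone; 4-chloro-2-methylphenyl and 5-fluoro-2-methylphenyl on the same nitrogen would pull the two apart. Also open, from the compounds shown here alone, is how the response would behave with something other than a halogen or a methyl on this ring, such as a methoxy group or a nitrile.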